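The compounds below may be only part of what the source reports. "The series", "measured", "known", "first", "only" and "open" are said of these compounds alone.

Measured compounds in a functional assay on RPMI 8402 cells (Homo sapiens) for cytotoxicity; on this read-out lower numbers stand for stronger inhibition and higher numbers for weaker inhibition:
- compound 1, `N#Cc1ccc2[nH]c(-c3ccc4[nH]cnc4c3)nc2c1`: > 25000 nM
- compound 2, `c1cc(-c2ccc3[nH]c(-c4ccc5[nH]c(-c6ccc7[nH]cnc7c6)nc5c4)nc3c2)ccn1`: 35 nM
- compound 3, `c1ccc2[nH]c(-c3ccc4[nH]c(-c5ccc6[nH]cnc6c5)nc4c3)nc2c1`: 14000 nM

Compound 1 gives only a limit of this assay, (the limit of > 25000 nM in this assay, at which 1 of the 3 values shown sits), and no number. Among the two numbers that were obtained, compound 2 stands lowest; its nearest neighbour is compound 3, reached by the step of a 400-fold higher number from compound 2 to compound 3 (2.60 log units; beyond the scatter). The other measured step is an at least 1.7-fold lower number from compound 1 to compound 3 (0.25 log units; that floor lies within the scatter), whose floor does not exceed the scatter.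

Compound 4, `c1ccc(-c2ccc3[nH]c(-c4ccc5[nH]c(-c6ccc7[nH]cnc7c6)nc5c4)nc3c2)nc1`, is the next member of the series. It differs from compound 2 in one place: pyridin-2-yl in place of pyridin-4-yl on an aromatic carbon. For the measured compounds named here, the only measured step that touches this position is the one from compound 2 to compound 3, where the pyridin-4-yl is lost altogether and the number rises sharply. Compound 4 keeps a pyridyl ring at that carbon, so that large loss is not expected to repeat. Going by the values given here, no measured pair exchanges pyridin-4-yl for pyridin-2-yl, so the size of the present step is not anchored by data; a shift of the nitrogen within the ring is expected to cost little, at most a modest weakening.

For compound 4 in this assay a value of 80 nM is therefore estimated, within 20 nM to 400 nM, meaning an expected step of a 2.3-fold higher number from compound 2 to compound 4 (0.36 log units; beyond the scatter).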

Compound 4, half-maximal inhibitory concentration: 160 nM
Compound 4: the middle estimate sits 2.0-fold (0.30 log units) below what was measured; measured number inside the range.
By their numbers in this assay, from the lowest: compound 2; then compound 4; then compound 3. At a limit, above all of these: compound 1.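

In this assay the place of the ring nitrogen counts on its own: with the same atoms joined differently, the change gives a 4.6-fold higher number from compound 2 to compound 4 (0.66 log units; beyond the scatter) and so lies beyond the scatter. Most of the gain from a pyridyl ring on this aromatic carbon still survives the change, as pyridin-2-yl in place of hydrogen gives an 88-fold lower number from compound 3 to compound 4 (1.94 log units; beyond the scatter) and this step is clearly larger than the one between the two pyridyl groups. The data shown offer no measured basis for explaining why pyridin-4-yl and pyridin-2-yl differ here.

Still open, from the compounds shown here alone, is whether a ring nitrogen is needed at all on this carbon, which a phenyl group would test, and where pyridin-3-yl would fall relative to compound 2 and compound 4. Also open, going by these compounds, is whether a group other than an aromatic ring, such as a dimethylamino group or a carboxylic acid, could take the place of the pyridyl ring on this carbon in this assay without a loss on the scale seen for compound 3.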